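Phenoxy Analogue of a Bis(trifluoromethyl)benzoyl Piperidine Amide Series

The source may report more compounds than this note shows. Statements on the series, on what has been measured and on what is new or still open speak of the compounds shown alone.

Three compounds have been measured in an ADME assay on PC-3 cells (Homo sapiens) for cytotoxicity, read by WST assay, tested at 100 uM (on this read-out lower numbers stand for less inhibition and higher numbers for more inhibition at the one concentration tested (going by the name of the read-out)), so far:

Compound 1 `O=C(Nc1cccc(-c2ccco2)c1)C1CCCN(C(=O)c2cc(C(F)(F)F)cc(C(F)(F)F)c2)C1` gives 0% in this assay.
Compound 2 `O=C(Nc1cccc(Oc2ccccn2)c1)C1CCCN(C(=O)c2cc(C(F)(F)F)cc(C(F)(F)F)c2)C1` gives 0% in this assay.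
Compound 3 `O=C(Nc1cccc(CN2CCCC2)c1)C1CCCN(C(=O)c2cc(C(F)(F)F)cc(C(F)(F)F)c2)C1` gives 51% in this assay.

Compound 3 stands highest of the three numbers, and its steps to the other two compounds are both beyond the scatter: a number 51 percentage points higher from compound 1 to compound 3 (beyond the scatter) and a number 51 percentage points higher from compound 2 to compound 3 (beyond the scatter). By contrast, the two aryl-type substituents in compound 1 and compound 2 give numbers that are indistinguishable from each other, as no change at the digits printed from compound 1 to compound 2 (within the scatter) shows.

Compound 4 `O=C(Nc1cccc(Oc2ccccc2)c1)C1CCCN(C(=O)c2cc(C(F)(F)F)cc(C(F)(F)F)c2)C1` has not yet been measured. It differs from compound 3 as follows: phenoxy in place of (pyrrolidin-1-yl)methyl on an aromatic carbon. Among the measured steps, the one from compound 2 to compound 3 bears most directly on this change, since compound 2 also carries an aromatic ring joined through oxygen at the same aromatic carbon, and the step from compound 1 to compound 3 points the same way. Both were large rises on going to the (pyrrolidin-1-yl)methyl group, so removing that group in favour of phenoxy is expected to undo most of that rise. The step is therefore expected to be a number 46 percentage points lower from compound 3 to compound 4 (beyond the scatter), a large fall. Compound 4 is estimated at 5%, with a range from 0% to 25%.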

Compound 4, a percentage reported as inhibition, at one concentration (the size of the read-out at that concentration, not a potency): 1%
Beside the measured number, compound 4's estimate is 4 percentage points above it; low and high end bracket the measured number.
By their numbers in this assay, from the lowest: compounds 1, 2 and 4 (each within the scatter of the next); then compound 3.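

In this assay the change to phenoxy gives a number 50 percentage points lower from compound 3 to compound 4 (beyond the scatter), so a third group at this aromatic carbon, now a six-membered aromatic ring of carbon only joined through oxygen, fails to keep the number seen with (pyrrolidin-1-yl)methyl. Taking away the ring nitrogen of the pyridin-2-yl group on the oxygen gives a number 1 percentage points higher from compound 2 to compound 4 (within the scatter), and replacing furan-2-yl with phenoxy gives a number 1 percentage points higher from compound 1 to compound 4 (within the scatter), so among these four compounds (pyrrolidin-1-yl)methyl is the only group that stands apart, with furan-2-yl, (pyridin-2-yl)oxy and phenoxy all giving numbers within the scatter of one another. Nothing at hand accounts for why this one group differs from the other three.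

From the compounds shown here alone, what remains open is whether the difference belongs to the ring nitrogen of compound 3 or to its carbon-linked ring, which a cyclopentylmethyl group, with carbon in place of that nitrogen, would separate. Going by these compounds, it is also open whether an open-chain amine such as dimethylaminomethyl, or a pyrrolidin-1-yl group without the methylene link, would behave like compound 3 at this aromatic carbon.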